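Diethylsulfamoyl in Place of Benzoyl: Cytotoxicity Expected Unchanged

A few compounds are considered here, and "the series" means these few. Any claim that something is new, unique, unknown or untested is made for them only; others in the source may bear on it.

Compound 1 `COC(=O)c1cccc(C(=O)N2CCCC(C(=O)Nc3ccc(Cl)cc3)C2)c1` carries a methoxycarbonyl group on the outer ring of a shared core, and in an ADME assay on PC-3 cells (Homo sapiens) for cytotoxicity, read by WST assay, tested at 100 uM (on this read-out lower numbers stand for less inhibition and higher numbers for more inhibition at the one concentration tested (going by the name of the read-out)), compound 1 gives 0%. Compound 2 `O=C(c1ccccc1)c1cccc(C(=O)N2CCCC(C(=O)Nc3ccc(Cl)cc3)C2)c1` bears a benzoyl group at the same place, and in this assay compound 2 gives 0%. For the measured compounds named here, the single measured step, no change at the digits printed from compound 1 to compound 2 (within the scatter), shows that exchanging a phenyl for a methoxy on a carbonyl carbon left the read-out where it was. Compound 2 therefore stands level with compound 1 at the digits shown, with compound 1 as its only neighbour and no change between them beyond the scatter.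

Compound 3 `CCN(CC)S(=O)(=O)c1cccc(C(=O)N2CCCC(C(=O)Nc3ccc(Cl)cc3)C2)c1` differs from compound 2 by diethylsulfamoyl in place of benzoyl on an aromatic carbon. Going by the values given here, the only step that bears on this change is the one from compound 1 to compound 2, which was flat, so the substituent at this position has so far not moved the read-out at all. On that basis no shift beyond the scatter is expected, and the step of no change at the digits printed from compound 2 to compound 3 (within the scatter) is estimated to be essentially nil. Compound 3 is thus expected to show 0% in this assay, with a range from 0% to 15%.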

Compound 3, a percentage reported as inhibition, at one concentration (the size of the read-out at that concentration, not a potency): 0%
The estimate for compound 3 equals the measured number at the digits printed; low and high end bracket the measured number.
By their numbers in this assay, from the lowest: compounds 1, 2 and 3 (each within the scatter of the next).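

In this assay the exchange of benzoyl for diethylsulfamoyl gave no change at the digits printed from compound 2 to compound 3 (within the scatter) and the exchange of methoxycarbonyl for diethylsulfamoyl gave no change at the digits printed from compound 1 to compound 3 (within the scatter) on the same aromatic carbon. Compound 1 and compound 2 both attach a carbonyl to this carbon, whereas compound 3 attaches a sulfamoyl group that brings sulfur and nitrogen and, unlike benzoyl, no ring, so the flat result now extends beyond carbonyl-linked groups to a group of a different kind. The three compounds therefore show no difference at this position across these groups, although nothing among the measurements given here explains that lack of response.

All three compounds sit at the same level, so the series does not yet show whether any group at this place can raise the read-out in this assay at all. A primary amine or a carboxylic acid at this position remains open, as does a longer chain than ethyl on the sulfamoyl nitrogen, and the compounds shown also leave open whether changing the chlorine elsewhere on the shared core would alter the result.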